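Hydroxy to methoxy: working notes on compound 3

The source may report more compounds than this note shows. Statements on the series, on what has been measured and on what is new or still open speak of the compounds shown alone.

compound 1 `O=C(NCCCNc1cc(-c2cn(-c3ccccc3)nc2-c2cccc(O)c2)ccn1)Nc1ccc(F)cc1` gives 3120 nM as measured
compound 2 `O=C(NCCCNc1cc(-c2cn(-c3ccccc3)nc2-c2cccc(O)c2)ccn1)Nc1cccc(C(F)(F)F)c1` gives 4490 nM as measured

Among the compounds with values here, in a functional assay on SK-OV-3 cells (Homo sapiens) for antiproliferative activity, read by sulforhodamine B assay, with a stated time of 48 h (a lower number here means a stronger inhibitor, a higher number a weaker inhibitor), compound 1 stands level with compound 2 within the scatter, and no other measured compound is available for comparison. Compound 3 `COc1cccc(-c2nn(-c3ccccc3)cc2-c2ccnc(NCCCNC(=O)Nc3ccc(F)cc3)c2)c1` differs from compound 1 at one place: methyl in place of hydrogen on an oxygen on an aromatic ring (methyl in place of hydrogen on an oxygen on an aromatic ring, hydroxy to methoxy). Within the data shown here, no measured step tests this change. Among the measured compounds shown here, the single step of a 1.4-fold higher number from compound 1 to compound 2 (0.16 log units; within the scatter) lies at another place, on an amide-type nitrogen, and serves only as a loose guide to size. For the measured compounds named here, no measured compound shows the direction, so no step beyond the scatter is expected in this assay for now. The estimated step is a 1.3-fold higher number from compound 1 to compound 3 (0.11 log units; within the scatter) and remains an expectation only. The expected value for compound 3 is 4000 nM with an estimated range of 1500 nM to 11000 nM as a working figure.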

Compound 3, half-maximal inhibitory concentration: 10800 nM
Compound 3: middle estimate off by 2.7-fold (0.43 log units), on the low side; the range from low to high includes it.
By their numbers in this assay, from the lowest: compounds 1 and 2 (each within the scatter of the next); then compound 3.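

In this assay, within the data shown here, methyl in place of hydrogen on this oxygen gives a 3.5-fold higher number from compound 1 to compound 3 (0.54 log units; beyond the scatter), which shows for the first time a direction at this position: hydroxy to methoxy raises the number, so compound 3 is the weaker inhibitor. Among these compounds, this is also the first step to lie beyond the scatter, whereas a 1.4-fold higher number from compound 1 to compound 2 (0.16 log units; within the scatter) at the amide-type nitrogen stays within it. No supporting measurement bears on this step, and its cause remains unassigned.

With one replacement at this oxygen, the compounds shown cannot separate loss of the hydrogen from gain of the methyl; an ethoxy group, or an amine in place of the hydroxy, would bear on that. On these data alone, whether the step holds alongside the 3-(trifluoromethyl)phenyl group of compound 2 also stays open.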